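The compounds below may be only part of what the source reports. "The series", "measured", "known", "first", "only" and "open" are said of these compounds alone.

Among the compounds with values here, in a physicochemical assay for lipophilicity, measured as octanol-water partition (on this read-out higher numbers stand for higher lipophilicity and lower numbers for lower lipophilicity), compound 1 `CCCCCCCCc1cn(C/C=C(/C)CCC=C(C)C)nn1` gives 6.92, the highest of the three numbers measured so far. Compound 2 `CC(C)=CCC/C(C)=C/Cn1cc(-c2ccccc2)nn1` gives 4.91 and compound 3 `COC(=O)c1cn(C/C=C(\C)CCC=C(C)C)nn1` gives 3.2, and both sit well beyond the scatter from compound 1.

The next compound to be measured is compound 4 `CCCCCc1cn(C/C=C(/C)CCC=C(C)C)nn1`, which keeps the core of compound 1 and differs from it only in its chain: hydrogen in place of propyl on a saturated chain carbon, five bonds along the chain from an aromatic carbon. Put simply, this is hydrogen in place of propyl on a saturated chain carbon, five bonds along the chain from an aromatic carbon.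

Within the data shown here, only one measured step is available as a guide, and it is an imperfect one: a number 1.71 log units lower from compound 2 to compound 3 (beyond the scatter). Among the measured compounds shown here, that step swaps methoxycarbonyl in place of phenyl on an aromatic carbon, so it is not the same kind of change and no measured pair shows a chain being cut back. It does show that a single change on this core can move the number by a large amount. Here only carbon leaves and only hydrogen enters, so a clearly lower number is expected, somewhat smaller than that step. The expected change is a number 1.47 log units lower from compound 1 to compound 4 (beyond the scatter). For compound 4 the estimated value is 5.45, with an expected range from 5 to 5.9.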

Compound 4, partition coefficient: 5.45
Compound 4: the middle estimate sits on the measured number at the digits printed; the measured number falls inside the stated range.
By their numbers in this assay, from the lowest: compound 3; then compound 2; then compound 4; then compound 1.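

In this assay, hydrogen in place of propyl on a saturated chain carbon, five bonds along the chain from an aromatic carbon, gives a number 1.47 log units lower from compound 1 to compound 4 (beyond the scatter). The earlier step, a number 1.71 log units lower from compound 2 to compound 3 (beyond the scatter), involved a group on an aromatic carbon, so this pair adds a second kind of evidence: the read-out also moves when the change lies out on the saturated chain, and the step is large even though only 3 carbon heavy atoms leave, with no ring and no hydrogen-bond donors or acceptors among them. Nothing measured here accounts for the size of this step.

Going by these compounds, a single pair cannot show whether the number would shift by even amounts if the chain were shortened or lengthened in smaller stages, so the shape of the trend along the chain remains unknown. Also open is what would happen with a longer chain than that of compound 1, or with an amine or a carboxylic acid at this position, since the compounds shown carry only carbon and hydrogen there.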